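Phenyl in place of thiophene on a shared core

The source may hold more compounds than are shown below. What is called first, only, known or untested is meant among the compounds shown, and "the series" means these compounds.

compound 1 `Cn1cccc1-c1cc(-c2cccs2)nc(N)c1C#N`: > 100000 nM
compound 2 `CC1CCCc2c1[nH]c(=O)c(C#N)c2-c1cccn1C`: > 100000 nM

Compound 1 carries a thiophen-2-yl group on its core. In a functional assay on BT-549 cells (Homo sapiens) for inhibition, read by sulforhodamine B assay, with a stated time of 48 h (a higher number here means a weaker inhibitor of growth, a lower number a stronger inhibitor of growth), compound 1 gives > 100000 nM, which is a limit of the assay and not a number. For the measured compounds named here, compound 2, built on a different core, is the only other compound measured, and in this assay compound 2 gives > 100000 nM, again a limit. Going by the values given here, compound 1 therefore stands on nothing more than a limit, and the one further value shown is a limit as well, as both sit at the limit of > 100000 nM in this assay, at which 2 of the 2 values shown sit. Among the compounds with values here, no step between two measured compounds that differ in one place exists here, so there is no measured change to lean on.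

Compound 3 `Cn1cccc1-c1cc(-c2ccccc2)nc(N)c1C#N` differs from compound 1 by phenyl in place of thiophen-2-yl on an aromatic carbon. Within the data shown here, with no measured step available, the expectation rests on compound 1 alone, whose value is a limit, and for this change no step beyond the scatter is expected; the estimated step is a step that the limit leaves unreadable from compound 1 to compound 3. Compound 3 is estimated at 150000 nM, with a range from 30000 nM to 600000 nM, and most likely this assay will again report only a limit.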

Compound 3, concentration for 50% growth inhibition: 60200 nM
The estimate for compound 3 lay 2.5-fold (0.40 log units) above the measured number; low and high end bracket the measured number.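

With phenyl on the aromatic carbon next to the ring nitrogen, compound 3 gives 60200 nM in this assay, the first number shown in this series that is not a limit. Compound 1, with thiophen-2-yl at that place, gives > 100000 nM, which is a limit of the assay. Read as an at least 1.6-fold lower number from compound 1 to compound 3 (0.22 log units; that floor lies within the scatter), the change from thiophen-2-yl to phenyl has only a floor for its size, because compound 1 stands at a limit of the assay: the limit of > 100000 nM in this assay, at which 2 of the 3 values shown sit.

On these data alone, it remains open whether a phenyl carrying a methoxy group or a fluorine, or a saturated ring such as cyclohexyl, would shift the number at this place. Also open is how the number would respond if the amino group gave way to a hydroxyl group, or if the 1-methyl-1H-pyrrol-2-yl group gave way to another ring such as pyridine, since the compounds shown change only the one place on the shared core.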